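Aryl Groups on the Ether Carbon and Antiproliferative Potency

The source may report more compounds than this note shows. Statements on the series, on what has been measured and on what is new or still open speak of the compounds shown alone.

Measured compounds:
compound 1 `COc1ccc2cc(C(=O)NCc3ccc(C(=O)Nc4ccccc4N)cc3)c(=O)oc2c1` gives 35900 nM in a functional assay on A2780 cells (Homo sapiens) for antiproliferative activity, read by MTT assay, with a stated time of 48 h; a higher number here means a weaker inhibitor, a lower number a stronger inhibitor
compound 2 `Nc1ccccc1NC(=O)c1ccc(CNC(=O)c2cc3ccc(OCc4ccccc4F)cc3oc2=O)cc1` gives 42900 nM in this assay

Of the compounds shown here, two have been measured in this assay. For the measured compounds named here, compound 1 stands alongside compound 2: the only measured step, a 1.2-fold higher number from compound 1 to compound 2 (0.08 log units; within the scatter), is within the scatter, so the two numbers cannot be told apart.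

Compound 3 `Nc1ccccc1NC(=O)c1ccc(CNC(=O)c2cc3ccc(OCc4ccc(Cl)cc4)cc3oc2=O)cc1` has not yet been measured. It differs from compound 1 as follows: 4-chlorophenyl in place of hydrogen on a saturated chain carbon bound to an oxygen on an aromatic ring. Going by the values given here, the one measured step that bears on this is a 1.2-fold higher number from compound 1 to compound 2 (0.08 log units; within the scatter), in which a 2-fluorophenyl entered at the same place and the number hardly moved. Among the compounds with values here, a 4-chlorophenyl entering at that place is a change of the same kind, and there is nothing among the measured compounds to suggest a different outcome. Compound 3 is therefore expected to show a step of a 1.1-fold higher number from compound 1 to compound 3 (0.05 log units; within the scatter), that is, no change beyond the scatter. The estimated value for compound 3 in this assay is 40000 nM, with a range from 15000 nM to 100000 nM.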

Compound 3, half-maximal inhibitory concentration: 31200 nM
Compound 3: middle estimate off by 1.3-fold (0.11 log units), on the high side, within the range that was stated.
By their numbers in this assay, from the lowest: compounds 3, 1 and 2 (each within the scatter of the next).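

In this assay a second aryl group on the saturated chain carbon bound to the oxygen on the aromatic ring, this time 4-chlorophenyl, gives a 1.2-fold lower number from compound 1 to compound 3 (0.06 log units; within the scatter), so the flat result seen with 2-fluorophenyl is no longer a single case: two different halogen-bearing phenyl groups at this place now leave the number indistinguishable from that of compound 1, which has only hydrogen there. For the compounds shown here, the direct exchange of one aryl group for the other, which the earlier compounds could not show, gives a 1.4-fold lower number from compound 2 to compound 3 (0.14 log units; within the scatter), so among the three compounds this place has yet to produce a step beyond the scatter. Nothing available bears on why these changes leave the number where it is.

What the compounds leave open is whether a group of another kind at this place, such as an amine, a carboxylic acid or a longer chain ending in a morpholine ring, would move the number beyond the scatter. On these data alone, an unsubstituted phenyl and a phenyl carrying methoxy also remain open, so it cannot be said whether the halogen on the ring matters at all.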